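This account rests on a few compounds, and the source may have more. Where it says the series, first, only, none or still open, it means among the compounds named here.

Compound 2 `COc1ccc(C2=Nn3c(nnc3C(C)c3ccc(-c4ccccc4)c(F)c3)SC2)cc1` gives 4200 nM in a functional assay on HepG2 cells (Homo sapiens) for inhibition, read by sulforhodamine B assay, with a stated time of 72 h (on this read-out higher numbers stand for weaker inhibition and lower numbers for stronger inhibition), the lowest of the two numbers at hand, and compound 1 `CC(c1ccc(-c2ccccc2)c(F)c1)c1nnc2n1N=C(c1ccc(Cl)cc1Cl)CS2` gives 8600 nM in this assay. For the measured compounds named here, the single measured step, a 2.0-fold lower number from compound 1 to compound 2 (0.31 log units; beyond the scatter), exchanged one whole aryl group for another. Compound 3 `CC(c1ccc(-c2ccccc2)c(F)c1)c1nnc2n1N=C(c1ccc(Cl)cc1)CS2` is not yet measured; it differs from compound 2 in that (chloro in place of methoxy on an aromatic carbon). Going by the values given here, only that earlier step bears on this change, and it swapped a different pair of groups, so a modest rise or no step beyond the scatter is expected, which is a 1.4-fold higher number from compound 2 to compound 3 (0.15 log units; within the scatter). Compound 3 is estimated at 6000 nM, within 2500 nM to 14000 nM.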

Compound 3, half-maximal inhibitory concentration: 6700 nM
For compound 3 the middle estimate is 1.1-fold (0.05 log units) below the measured one; the measured number falls inside the stated range.
By their numbers in this assay, from the lowest: compounds 2, 3 and 1 (each within the scatter of the next, the first and the last beyond it).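

In this assay the exchange of 4-methoxyphenyl for 4-chlorophenyl gives a 1.6-fold higher number from compound 2 to compound 3 (0.20 log units; within the scatter) and the loss of one chloro from the aromatic ring gives a 1.3-fold lower number from compound 1 to compound 3 (0.11 log units; within the scatter) as well. The earlier step beyond the scatter thus divides into two smaller changes on this aryl group, neither of them beyond the scatter alone. No evidence at hand accounts for these numbers. The compounds shown leave open whether an amine or a carboxylic acid on this aromatic carbon would move the number beyond the scatter. They also leave open how a change on the fluorinated biphenyl part would read.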